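The source may report more compounds than this note shows. Statements on the series, on what has been measured and on what is new or still open speak of the compounds shown alone.

In a functional assay on MCF7 cells (Homo sapiens) for cytotoxicity, read by MTT assay (on this read-out higher numbers stand for weaker inhibition and lower numbers for stronger inhibition), the measured values are

compound 1 `COC(=O)C[C@@H]1C[C@@H](O)[C@H](C)[C@H](c2ccccc2)N1` gives 5400 nM
compound 2 `COC(=O)C[C@H]1C[C@@H](O)[C@H](C)[C@@H](c2ccccc2)N1` gives 35600 nM

Compound 2 holds the higher of the two numbers, and so the weaker inhibition. Compound 3 `COC(=O)C[C@H]1C[C@H](O)[C@H](C)[C@@H](c2ccccc2)N1` has the same atoms and bonds as compound 2 (the two compounds have the same atoms and bonds and differ only in configuration as drawn: 1 of 4 stereo elements differ; a stereocentre at a saturated ring carbon is drawn R in compound 2 and S in compound 3). For the measured compounds named here, one measured step bears on this (a 6.6-fold higher number from compound 1 to compound 2 (0.82 log units; beyond the scatter)), a modest change traced to the fact that compounds 1 and 2 differ only in the configuration as drawn alone. Fewer stereo elements differ here than in that step, so a smaller step is expected, probably towards stronger inhibition, though the direction is uncertain. The estimated step is a 1.8-fold lower number from compound 2 to compound 3 (0.25 log units; within the scatter). The expected value for compound 3 is 20000 nM (6000 nM to 60000 nM).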

Compound 3, half-maximal inhibitory concentration: "not active" (no number reported)
Compound 3 has no reported number here, so the estimate cannot be set against anything.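

For the compounds shown here, compound 3 is reported only as "not active", without a number, so no step to compound 3 from compound 1 or compound 2 can be read. The compounds shown leave open how large an effect that single changed stereocentre has.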